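A Methoxy Step Tested Against a Cytotoxicity Ceiling

The source may hold more compounds than are shown below. What is called first, only, known or untested is meant among the compounds shown, and "the series" means these compounds.

Measured so far:
- compound 1, `COc1ccc(-c2nc3cc(/C(C)=N/O)ccc3[nH]2)c(OC)c1`; in an ADME assay on BHK-21 cells (Mesocricetus auratus) for cytotoxicity, read by MTT assay (a higher number here means that more compound is tolerated, a lower number that less compound is tolerated), compound 1 gives > 100000 nM, which is a limit of the assay.
- compound 2, `COc1ccc(-c2nc3cc(/C(C)=N/O)ccc3[nH]2)c(OC)c1OC`; in this assay compound 2 gives > 100000 nM, again a limit of the assay.
- compound 3, `COc1ccc(-c2nc3cc(/C(C)=N/NC(N)=O)ccc3[nH]2)cc1`; in this assay compound 3 gives "not determined" (no result reported), so no result is reported for it.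

The step that the two limits leave unreadable from compound 1 to compound 2 is made by methoxy in place of hydrogen on an aromatic carbon. Because both of its end points sit at the limit of > 100000 nM in this assay, at which 2 of the 3 values shown sit, the size of that step cannot be read. Compound 4, `COc1ccc(-c2nc3cc(/C(C)=N/NC(N)=O)ccc3[nH]2)c(OC)c1`, is not yet measured, and it differs from compound 3 by methoxy in place of hydrogen on an aromatic carbon. The surroundings of the place are not the same: in the step from compound 1 to compound 2 the new group sits ortho to two methoxy groups (2 heavy atoms each) and meta to a large group, whereas in the step from compound 3 to compound 4 it sits ortho to a large group and meta to a methoxy group (2 heavy atoms). It is therefore the same kind of change, not the same change. The difference between the core of compound 1 and the core of compound 3 is not broken down here.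

Within the data shown here, no step can be given for compound 4 in this assay, so only an estimate can stand. Compound 4 is expected to come out near 150000 nM, within 60000 nM to 400000 nM, and the most likely outcome is expected to be another limit, since compound 1 and compound 2 both rest at the limit of > 100000 nM in this assay, at which 2 of the 3 values shown sit, and the same kind of change is being made.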

Compound 4, half-maximal cytotoxic concentration: >= 100000 nM
Compound 4 gave a limit, no number (the forecaster's own chance of this, stated with the estimate: 75%); the middle value is on the limit's open side.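

In this assay compound 4 gives >= 100000 nM, which is a limit of the assay and not a number. Among these compounds, compound 1 also rests at a limit, so the step between compound 1 and compound 4 cannot be read, and no new step emerges. The compounds shown leave open how much of compound 1, compound 2 or compound 4 is tolerated beyond these limits, and whether methoxy in place of hydrogen on an aromatic carbon changes that.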